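A few compounds are considered here, and "the series" means these few. Any claim that something is new, unique, unknown or untested is made for them only; others in the source may bear on it.

Compound 1 `CC(=O)c1ccc(NC2=NCCC3(CCCCC3)S2)cc1` — 1.97 in a physicochemical assay for lipophilicity, measured as octanol-water partition, at pH 7.4; on this read-out higher numbers stand for higher lipophilicity and lower numbers for lower lipophilicity
Compound 2 `Nc1ccc(NC2=NCCC3(CCCCC3)S2)cc1` — 1.88 in this assay

Compound 2 gives the lower of the two numbers, its nearest neighbour being compound 1, with the step of a number 0.09 log units lower from compound 1 to compound 2 (within the scatter). Compound 3 `Cc1ccc(NC2=NCCC3(CCCCC3)S2)cc1` is obtained from compound 2 by methyl in place of amino on an aromatic carbon. Among the compounds with values here, the only measured step swaps acetyl for amino and does not match this change, so it offers little guidance. Compound 3 is nevertheless expected to sit higher than compound 2, by an estimated a number 1.02 log units higher from compound 2 to compound 3 (beyond the scatter), giving an estimate of 2.9 within 2.5 to 3.3.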

Compound 3, distribution coefficient: 1.56
Estimate against measurement, compound 3: 1.34 log units above, outside the stated range (below it).
By their numbers in this assay, from the lowest: compound 3; then compounds 2 and 1 (each within the scatter of the next).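

In this assay, the aromatic carbon para to a large group now shows a change beyond the scatter: methyl in place of amino gives a number 0.32 log units lower from compound 2 to compound 3 (beyond the scatter), and methyl in place of acetyl gives a number 0.41 log units lower from compound 1 to compound 3 (beyond the scatter). Amino and acetyl did not separate at this position, so methyl is the first group here to stand apart from both, and it gives the lowest number. Nothing available accounts for this result.

From the compounds shown here alone, it remains open where a carboxylic acid, a methoxy group or a longer chain such as propyl would fall at this position. Whether methyl would stay lowest beside them is also unresolved.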